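The source may report more compounds than this note shows. Statements on the series, on what has been measured and on what is new or still open speak of the compounds shown alone.

Measured compounds:
Compound 1 `O=C(NC1CCCC1)c1ccc(C#Cc2ccccc2)nc1` gave 3300 nM in an assay on HEK293 cells for displacement of a labelled ligand from metabotropic glutamate receptor 5 (Homo sapiens), with a stated time of 2 h; on this read-out higher numbers stand for weaker inhibition and lower numbers for stronger inhibition.
Compound 2 `Cc1cccc(C#Cc2ccc3c(n2)CCN(C(C)C)C3=O)c1` gave 510 nM.
Compound 3 `CC(C)N1CCc2nc(C#Cc3ccccc3Cl)ccc2C1=O` gave 5680 nM.

Among these three, compound 3 carries the highest number in this assay. Compound 1 sits within the usual scatter of compound 3, so the two cannot be told apart. Compound 2 is clearly separated: the step of an 11-fold higher number from compound 2 to compound 3 (1.05 log units; beyond the scatter) is large and well beyond the scatter, and it arises from a single change at the group on the triple-bonded carbon.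

The new compound 4 `CC(C)N1CCc2nc(C#Cc3ccccn3)ccc2C1=O` differs from compound 3 at the same position: pyridin-2-yl in place of 2-chlorophenyl on a triple-bonded carbon. Going by the values given here, the only measured step that bears on this position is the one from compound 2 to compound 3, which showed that the group on the triple-bonded carbon can move the number by a large amount. Among the compounds with values here, no pyridin-2-yl analogue has been measured, so the direction rests on the observation that compound 3, with the 2-chlorophenyl, stands at the high end, while compound 1 and compound 2 with plain or methyl-bearing phenyl rings stand lower. A step down in the number is therefore expected, of moderate size, with wide uncertainty: a 3.8-fold lower number from compound 3 to compound 4 (0.58 log units; beyond the scatter). Compound 4 is estimated at 1500 nM, within a range from 400 nM to 5500 nM.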

Compound 4, inhibition constant: 2740 nM
Estimate against measurement, compound 4: 1.8-fold (0.26 log units) below, and the stated range covers the measured number.
By their numbers in this assay, from the lowest: compound 2; then compounds 4, 1 and 3 (each within the scatter of the next, the first and the last beyond it).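

In this assay, pyridin-2-yl in place of 2-chlorophenyl on a triple-bonded carbon gives a 2.1-fold lower number from compound 3 to compound 4 (0.32 log units; beyond the scatter) and so shows that this position also responds to a ring with a hetero atom, not only to changes among carbon-only rings. Set against the 3-methylphenyl group, the same ring gives a 5.4-fold higher number from compound 2 to compound 4 (0.73 log units; beyond the scatter) and leaves a clear gap on that side as well. On this core the pyridin-2-yl compound therefore falls between the two substituted phenyl compounds, with each gap beyond the scatter, and the earlier single step between those two compounds becomes a three-point series in which the new ring recovers only part of the distance.

The compounds shown leave open how an unsubstituted phenyl ring, a 3-chlorophenyl group, or pyridin-3-yl and pyridin-4-yl rings would read on this same core, and these would separate the effect of the substituent from that of its place and show whether the ring nitrogen's location matters. Why the three rings fall in this order also stays open, as nothing measured here gives a reason for it.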